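The source may report more compounds than this note shows. Statements on the series, on what has been measured and on what is new or still open speak of the compounds shown alone.

Compound 1 `CCC(C(=O)N1CCN(c2ccccc2Cl)CC1)N1C(=O)CCC1=O`: 0%
Compound 2 `CC(C(=O)N1CCN(c2ccccc2Cl)CC1)N1C(=O)CCC1=O`: 0%
Compound 3 `CC(C(=O)N1CCN(c2cccc(Cl)c2)CC1)N1C(=O)CCC1=O`: 50%

All three compounds were tested in a functional assay on the whole organism (strain Swiss) with Mus musculus as the target, in the maximal electroshock model, with a stated time of 2 h, at a dose of 300 mg/kg by the intraperitoneal route; a higher number here means a stronger effect of the compound at the dose given, a lower number a weaker effect. Compound 1 stands level with compound 2, the two together giving the lowest numbers of the set, while compound 3 stands far above them. The step of no change at the digits printed from compound 1 to compound 2 (within the scatter), which is hydrogen in place of methyl on a saturated chain carbon, two bonds along the chain from an amide-type nitrogen in a ring and a carbonyl carbon, shows that this part of the chain hardly matters here. The step of a number 50 percentage points higher from compound 2 to compound 3 (beyond the scatter), which is 3-chlorophenyl in place of 2-chlorophenyl on an amine nitrogen in a ring, shows that where the chloro sits on the aromatic ring matters greatly.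

Compound 4 `CCC(C(=O)N1CCN(c2ccccc2)CC1)N1C(=O)CCC1=O` differs from compound 1 by hydrogen in place of chloro on an aromatic carbon. Among the compounds with values here, no measured step removes the chloro altogether; the only step touching this ring changes its position. Since compound 1 with 2-chlorophenyl gives 0% and a changed arrangement gave a large rise, some rise is expected but with wide uncertainty, so the estimate for compound 4 is 25% (range 0% to 75%), a step of a number 25 percentage points higher from compound 1 to compound 4 (beyond the scatter).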

Compound 4, a percentage reported as activity, at one dose (the size of the read-out at that dose, not a potency): 25%
For compound 4 middle estimate and measured number coincide at the digits printed; the measured number falls inside the stated range.
By their numbers in this assay, from the lowest: compounds 1 and 2 (each within the scatter of the next); then compound 4; then compound 3.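

Putting hydrogen in place of chloro on the aromatic carbon gives a number 25 percentage points higher from compound 1 to compound 4 (beyond the scatter), so the change from 2-chlorophenyl to phenyl has a real effect on the core of compound 1. The earlier compounds shown here showed only that moving the chloro around the ring matters; this step adds that, in this assay, the ring carries more activity with no group at this place, ortho to a large group, than with chloro there. Nothing available here gives a reason for this rise.

The compounds shown leave open whether a fluoro or a methoxy group at this place would behave more like the chloro or more like hydrogen. Also open, as far as these compounds go, is whether the same swap gives a rise of similar size on the chain of compound 2.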